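Moving the Methyl Around the Pyridinyl Ring

The compounds below may be only part of what the source reports. "The series", "measured", "known", "first", "only" and "open" are said of these compounds alone.

Compound 1 `Cc1nc(CN2CCC[C@H]2c2ccccn2)cc(N2CCN(C)CC2)n1`: 220 nM
Compound 2 `Cc1ccnc([C@@H]2CCCN2Cc2cc(N3CCN(C)CC3)nc(C)n2)c1`: 216 nM
Compound 3 `Cc1ccc([C@@H]2CCCN2Cc2cc(N3CCN(C)CC3)nc(C)n2)nc1`: 278 nM

These three compounds were measured in an assay on HPBALL cells for binding affinity to C-X-C chemokine receptor type 4 (Homo sapiens), read by flow cytometry, with a stated time of 3 h; on this read-out lower numbers stand for stronger inhibition and higher numbers for weaker inhibition. Compound 3 sits level with the other two: the step of a 1.3-fold higher number from compound 1 to compound 3 (0.10 log units; within the scatter) and the step of a 1.3-fold higher number from compound 2 to compound 3 (0.11 log units; within the scatter) both fall within the scatter, as does the step of a 1.0-fold lower number from compound 1 to compound 2 (0.01 log units; within the scatter). Compound 4 `Cc1cccc([C@@H]2CCCN2Cc2cc(N3CCN(C)CC3)nc(C)n2)n1` has not yet been measured. It differs from compound 3 in one place: 6-methylpyridin-2-yl in place of 5-methylpyridin-2-yl on a saturated ring carbon. Among the measured compounds shown here, the steps that bear on this change are the three already described, each a change of a methyl on the pyridinyl ring, and none of them moved the number beyond the scatter. For the measured compounds named here, no measured pair tests the 6-methylpyridin-2-yl group itself, so the expectation rests on those three steps alone. Compound 4 is therefore expected to show no step beyond the scatter in this assay, with a 1.0-fold higher number from compound 3 to compound 4 (0.02 log units; within the scatter). Compound 4 is estimated at 290 nM, with a range from 130 nM to 650 nM.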

Compound 4, half-maximal inhibitory concentration: 2390 nM
For compound 4 the middle estimate is 8.2-fold (0.92 log units) below the measured one; measured number outside the range, above it.
By their numbers in this assay, from the lowest: compounds 2, 1 and 3 (each within the scatter of the next); then compound 4.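

Moving the methyl to give the 6-methylpyridin-2-yl group produces an 8.6-fold higher number from compound 3 to compound 4 (0.93 log units; beyond the scatter) and also an 11-fold higher number from compound 2 to compound 4 (1.04 log units; beyond the scatter) even though the 5-methylpyridin-2-yl and 4-methylpyridin-2-yl groups stayed within the scatter of each other. Set against the unmethylated ring, the same group gives an 11-fold higher number from compound 1 to compound 4 (1.04 log units; beyond the scatter) whereas the two other methyl placements left the number within the scatter. The groups that leave and enter have the same atoms and the same counts, so on this read-out the pyridinyl ring does not accept a methyl equally at every ring carbon, and only where the methyl sits separates compound 4 from compound 3.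

Going by these compounds, it remains open whether this step belongs to methyl itself or would recur with a chlorine, a methoxy or an amine on that same ring carbon. Nothing measured and shown here offers an explanation for the step.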